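Imidazoline series: open-chain oxime ether replaces thiazole

The source may hold more compounds than are shown below. What is called first, only, known or untested is meant among the compounds shown, and "the series" means these compounds.

Compound 2 `Cc1nc(-c2ccccc2NCC2=NCCN2)cs1` gives 4.47 nM in a functional assay for activation of Alpha-1A adrenergic receptor (Homo sapiens), read by calcium flux (on this read-out lower numbers stand for an effect already at smaller amounts and higher numbers for an effect only at larger amounts of compound), the lowest of the three numbers measured. Compound 1 `Cc1ncc(-c2ccccc2NCC2=NCCN2)o1` gives 110 nM and compound 3 `Cc1cc(-c2ccccc2NCC2=NCCN2)on1` gives 38.9 nM in this assay. Compound 4 `CCO/N=C(\C)c1ccccc1NCC1=NCCN1` has not been measured; it differs from compound 2 by a group of 6 heavy atoms (4 carbon, 1 nitrogen, 1 oxygen; no ring) in place of a group of 6 heavy atoms (4 carbon, 1 nitrogen, 1 sulfur; one five-membered aromatic ring with 2 hetero atoms), on an aromatic carbon. Among the compounds with values here, the steps that bear on this are a 25-fold lower number from compound 1 to compound 2 (1.39 log units; beyond the scatter) and an 8.7-fold higher number from compound 2 to compound 3 (0.94 log units; beyond the scatter), both swaps of one five-membered aromatic ring for another; no measured step removes the ring altogether, so the expectation rests on the sensitivity those steps reveal. A higher number is expected for compound 4, with wide uncertainty: a 13-fold higher number from compound 2 to compound 4 (1.13 log units; beyond the scatter). Compound 4 is estimated at 60 nM, within 12 nM to 300 nM.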

Compound 4, half-maximal effective concentration: 52.5 nM
Beside the measured number, compound 4's estimate is 1.1-fold (0.06 log units) above it; the range from low to high includes it.
By their numbers in this assay, from the lowest: compound 2; then compounds 3 and 4 (each within the scatter of the next); then compound 1.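

The open-chain group shows that a five-membered aromatic ring is not needed for activity at this position, on an aromatic carbon of the shared core: in this assay there is a 1.3-fold higher number from compound 3 to compound 4 (0.13 log units; within the scatter) and a 2.1-fold lower number from compound 1 to compound 4 (0.32 log units; beyond the scatter). Only the 2-methyl-1,3-thiazol-4-yl group goes against this, with a 12-fold higher number from compound 2 to compound 4 (1.07 log units; beyond the scatter). No measurement here accounts for these steps. From the compounds shown here alone, it remains open whether a longer chain or an amine at the ethyl end of the new group would bring the number closer to that of compound 2.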